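A further methoxy group on compound 3

The source may hold more compounds than are shown below. What is called first, only, known or untested is meant among the compounds shown, and "the series" means these compounds.

Compound 1 `COc1ccc(N(C)c2ncnc3c2ncn3C)cc1`: > 100000 nM (a limit of the assay)
Compound 2 `COc1ccc(N(C)c2nc(Cl)nc3c2ncn3C)cc1`: 3400 nM
Compound 3 `COc1ccc(N(C)c2ncnc3c2ncn3Cc2ccc(OC)c(OC)c2)cc1`: 430 nM

All three compounds were tested in a functional assay on SH-SY5Y cells (Homo sapiens) for antiproliferative activity, read by MTT assay, with a stated time of 48 h; on this read-out lower numbers stand for stronger inhibition of growth and higher numbers for weaker inhibition of growth. The entry for compound 1 is a limit, not a number. Of the two true numbers, compound 3 has the lower one, and its gap to compound 2 lies beyond the scatter.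

Compound 4 `COc1ccc(N(C)c2ncnc3c2ncn3Cc2cc(OC)c(OC)c(OC)c2)cc1` is compound 3 with one change: methoxy in place of hydrogen on an aromatic carbon. Two measured steps offer some guidance, and both start from the limit. The closer one is the large step of an at least 230-fold lower number from compound 1 to compound 3 (2.36 log units; beyond the scatter), which brought in the 3,4-dimethoxyphenyl group, the group that now gains the methoxy. The other is the large step of an at least 29-fold lower number from compound 1 to compound 2 (1.46 log units; beyond the scatter), where chloro replaced hydrogen on an aromatic carbon of the core. Neither step measures a methoxy added at this place, so their size does not carry over. Compound 4 keeps everything that separates compound 3 from compound 1, so only a modest shift is expected in this assay, with no firm direction. The expected step of a 1.2-fold higher number from compound 3 to compound 4 (0.07 log units; within the scatter) is likely to stay within the scatter. For compound 4 the estimated value is 500 nM, with an expected range from 120 nM to 2500 nM.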

Compound 4, concentration for 50% growth inhibition: 260 nM
Compound 4: the middle estimate sits 1.9-fold (0.28 log units) above what was measured; the range from low to high includes it.
By their numbers in this assay, from the lowest: compounds 4 and 3 (each within the scatter of the next); then compound 2. At a limit, above all of these: compound 1.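

In this assay, the 3,4-dimethoxyphenyl group of compound 3 takes a further methoxy on an aromatic carbon ortho to a methoxy group, giving a 1.7-fold lower number from compound 3 to compound 4 (0.22 log units; within the scatter), so the two compounds cannot be told apart in this read-out. Among these compounds, the earlier steps showed what the whole 3,4-dimethoxyphenyl group and a chloro on the core could do, whereas this is the first step made on that ring itself, and it shows that the activity of compound 3 survives when this aromatic carbon loses its hydrogen to a methoxy. Nothing given here accounts for this tolerance.

Going by these compounds, only methoxy has been seen at this carbon, so it remains open whether a group of a different kind there, such as an amine or a carboxylic acid, would be tolerated in the same way. Also open is how the chloro of compound 2 would behave together with the larger aromatic group of compound 3 or compound 4, since none of the compounds shown carries both.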